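Methyl for nitro at the phenoxymethyl end

The compounds below may be only part of what the source reports. "The series", "measured", "known", "first", "only" and "open" are said of these compounds alone.

Compound 1 `N#Cc1ccc(C(c2ccc(C#N)cc2)n2cc(C3CCCCC3)nn2)cc1` gives 19300 nM in an assay on isolated protein for inhibition of Aromatase (Homo sapiens), read by fluorescence and colorimetric assay, with a stated time of 30 min; a higher number here means a weaker inhibitor, a lower number a stronger inhibitor. Compound 2 `N#Cc1ccc(C(c2ccc(C#N)cc2)n2cc(COc3ccc(Cl)cc3)nn2)cc1` gives 16100 nM in this assay, and compound 3 `N#Cc1ccc(C(c2ccc(C#N)cc2)n2cc(COc3ccc([N+](=O)[O-])cc3)nn2)cc1` gives 7730 nM in this assay, the lowest of the three numbers. The step of a 2.1-fold lower number from compound 2 to compound 3 (0.32 log units; beyond the scatter) and the step of a 2.5-fold lower number from compound 1 to compound 3 (0.40 log units; beyond the scatter) both lie beyond the scatter, while a 1.2-fold lower number from compound 1 to compound 2 (0.08 log units; within the scatter) does not.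

Compound 4 `Cc1ccc(OCc2cn(C(c3ccc(C#N)cc3)c3ccc(C#N)cc3)nn2)cc1` differs from compound 3 by methyl in place of nitro on an aromatic carbon. Within the data shown here, no measured step swaps nitro for methyl directly; the only measured change on this aromatic carbon is a 2.1-fold lower number from compound 2 to compound 3 (0.32 log units; beyond the scatter), and exchanging the whole side group in a 1.2-fold lower number from compound 1 to compound 2 (0.08 log units; within the scatter) left the number where it was. On that basis, removing the nitro is expected to undo the modest gain seen with compound 3 and bring the number back toward the region of compound 2, with nothing in the data pointing to a larger move. Compound 4 is therefore expected to come in at about 15000 nM, within 7000 nM to 35000 nM. This estimate means a step of a 1.9-fold higher number from compound 3 to compound 4 (0.29 log units; within the scatter) in this assay.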

Compound 4, half-maximal inhibitory concentration: 11000 nM
Compound 4: the middle estimate sits 1.4-fold (0.13 log units) above what was measured; the measured number falls inside the stated range.
By their numbers in this assay, from the lowest: compounds 3, 4, 2 and 1 (each within the scatter of the next, the first and the last beyond it).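

At this aromatic carbon, methyl cannot be separated from nitro (a 1.4-fold higher number from compound 3 to compound 4 (0.15 log units; within the scatter)) or from chloro (a 1.5-fold lower number from compound 2 to compound 4 (0.17 log units; within the scatter)) in this assay, although nitro and chloro do separate (a 2.1-fold lower number from compound 2 to compound 3 (0.32 log units; beyond the scatter)). Against cyclohexyl, (4-methylphenoxy)methyl also stays within the scatter (a 1.8-fold lower number from compound 1 to compound 4 (0.24 log units; within the scatter)), so among the listed side groups only (4-nitrophenoxy)methyl has a step beyond the scatter from cyclohexyl, and compound 4 leaves that separation small and confined to compound 3 against compounds 1 and 2. No measurement on hand accounts for these numbers.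

From the compounds shown here alone, what an amine, a carboxylic acid or a longer chain on this aromatic carbon would give remains open. In this assay, going by these compounds, compound 3 gives 7730 nM, and whether any group here can give a much lower number on this core is also open.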